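From 2-chlorophenyl to 2-nitrophenyl: an expected step

The compounds below may be only part of what the source reports. "The series", "measured", "known", "first", "only" and "open" are said of these compounds alone.

Compound 1 (`Cc1ccc(N2CCN(C(=S)SCc3ccc4nc(N)nc(N)c4c3)CC2)cc1`) gives 2130 nM
Compound 2 (`Nc1nc(N)c2cc(CSC(=S)N3CCN(c4ccccc4Cl)CC3)ccc2n1`) gives 4050 nM

Only these two numbers are at hand in a functional assay on HeLa cells (Homo sapiens) for antiproliferative activity, read by MTT assay, with a stated time of 72 h (on this read-out lower numbers stand for stronger inhibition and higher numbers for weaker inhibition), so far. There compound 2 gives 4050 nM and lies within the scatter of compound 1, so neither can be ranked over the other. Compound 3 (`Nc1nc(N)c2cc(CSC(=S)N3CCN(c4ccccc4[N+](=O)[O-])CC3)ccc2n1`) has not yet been measured. It differs from compound 2 by having nitro in place of chloro on an aromatic carbon, ortho to a large group (nitro in place of chloro on an aromatic carbon). For the measured compounds named here, the one measured step concerns the same aromatic group: 2-chlorophenyl in place of 4-methylphenyl on an amine nitrogen in a ring gave a 1.9-fold higher number from compound 1 to compound 2 (0.28 log units; within the scatter) and so stayed within the scatter. Going by the values given here, no measured compound carries nitro, which makes this step thin guidance. No step beyond the scatter is therefore expected in this assay and no firm direction can be given. The estimated step is a 1.4-fold lower number from compound 2 to compound 3 (0.13 log units; within the scatter) and it remains an expectation only. For compound 3 the expected value is 3000 nM with an estimated range from 1000 nM to 9000 nM as its bounds.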

Compound 3, half-maximal inhibitory concentration: 4880 nM
The estimate for compound 3 lay 1.6-fold (0.21 log units) below the measured number; the range from low to high includes it.
By their numbers in this assay, from the lowest: compounds 1, 2 and 3 (each within the scatter of the next, the first and the last beyond it).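

In this assay, nitro in place of chloro on an aromatic carbon, ortho to a large group, gave a 1.2-fold higher number from compound 2 to compound 3 (0.08 log units; within the scatter), so this place tolerates the exchange of chloro, with 1 heavy atom and 0 hydrogen-bond acceptors, for nitro, with 3 heavy atoms and 2 hydrogen-bond acceptors, without a change that can be read. For the compounds shown here, the comparison with the 4-methylphenyl compound gives the first step beyond the scatter, though a modest one: 2-nitrophenyl in its place gave a 2.3-fold higher number from compound 1 to compound 3 (0.36 log units; beyond the scatter), whereas 2-chlorophenyl, in compound 2, stayed within the scatter of compound 1. No measurement at hand speaks to the reason for either step.

The compounds shown leave open whether an amine or a carboxylic acid on this same aromatic carbon would also stay within the scatter of compound 2, or whether the tolerance seen here is limited to chloro and nitro. They also leave open how a plain phenyl group, carrying neither chloro, nitro nor methyl, would compare with compound 1 and compound 3.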